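A few compounds are considered here, and "the series" means these few. Any claim that something is new, unique, unknown or untested is made for them only; others in the source may bear on it.

Working notes on the series.

Compound 2 `O=C1/C(=C/c2cccnc2)CNC/C1=C\c1ccccc1C(F)(F)F` carries a trifluoromethyl on the phenyl ring; in a functional assay on SMMC-7721 cells (Homo sapiens) for cytotoxicity, read by MTT assay, with a stated time of 24 h (on this read-out higher numbers stand for weaker inhibition and lower numbers for stronger inhibition), compound 2 gives 5100 nM. Compound 1 `O=C1/C(=C/c2cccnc2)CNC/C1=C\c1ccccc1F` is the same core with fluoro in place of trifluoromethyl on an aromatic carbon. In this assay compound 1 gives only a limit, > 20000 nM, as a value of this kind is a boundary of the assay and not a number; this is the limit of > 20000 nM in this assay, at which 1 of the 3 values shown sits. The step from this change is an at least 3.9-fold higher number from compound 2 to compound 1 (0.59 log units; beyond the scatter).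

Compound 3 `O=C1/C(=C/c2ccncc2)CN(S(=O)(=O)c2ccc(C(F)(F)F)cc2)C/C1=C\c1ccccc1C(F)(F)F` belongs to a second core, with a sulfonyl-bearing aryl on the ring nitrogen; in this assay compound 3 gives 3840 nM. The difference between the two cores is not broken down here. Next to compound 2 the value of compound 3 sits within the scatter, so no order is read between them.

Compound 4 `O=C1/C(=C/c2ccncc2)CN(S(=O)(=O)c2ccc(F)cc2)C/C1=C\c1ccccc1C(F)(F)F` is not yet measured. It differs from compound 3 by fluoro in place of trifluoromethyl on an aromatic carbon. This is the same kind of change as from compound 2 to compound 1, though the place differs: there the fluoro sits ortho to a large group, here para to a large group. The earlier change weakened inhibition, as an at least 3.9-fold higher number from compound 2 to compound 1 (0.59 log units; beyond the scatter) shows, so a step toward a higher number is expected for compound 4 as well, though with a different surround the size carries uncertainty. Compound 4 is expected to show a step of a 2.1-fold higher number from compound 3 to compound 4 (0.32 log units; beyond the scatter) in this assay. Compound 4 is therefore estimated at 8000 nM in this assay, between 3500 nM and 20000 nM.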

Compound 4, half-maximal inhibitory concentration: 9270 nM
Compound 4: middle estimate off by 1.2-fold (0.06 log units), on the low side; the measured number falls inside the stated range.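

In this assay, fluoro in place of trifluoromethyl gives a 2.4-fold higher number from compound 3 to compound 4 (0.38 log units; beyond the scatter), so on the core of compound 3, in the change from 4-(trifluoromethyl)phenyl to 4-fluorophenyl, the number moves in the same direction as on the core of compound 1. Set side by side, the two steps read: the same change on two cores in this assay, an at least 3.9-fold higher number (0.59 log units; beyond the scatter) from compound 2 to compound 1 and a 2.4-fold higher number (0.38 log units; beyond the scatter) from compound 3 to compound 4; the limit leaves it open whether they differ

Compound 1 gives > 20000 nM, which is a limit of the assay and not a number, so the two pairs show a shared direction on two cores but do not show that the size of the step carries over from one core to the other.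

The compounds shown leave open whether the direction would hold for other replacements of trifluoromethyl, such as a chloro, a methoxy, a nitrile, an amine or a carboxylic acid, and whether it extends beyond these two pairs. They also leave open what the sulfonyl-bearing aryl on the ring nitrogen contributes by itself, as no pair shown differs in that one place alone.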